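This account rests on a few compounds, and the source may have more. Where it says the series, first, only, none or still open, it means among the compounds named here.

Measured so far in an assay on a protein complex for inhibition of CDK8/Cyclin C (Homo sapiens), with a stated time of 1 h; on this read-out higher numbers stand for weaker inhibition and lower numbers for stronger inhibition:

- compound 1, `CCOC(=O)/C=C/c1ccncc1-c1ccc2[nH]ccc2c1`: 107 nM
- compound 2, `Cn1ccc2cc(-c3cnccc3/C=C/C(=O)O)ccc21`: 26.8 nM
- compound 3, `O=C(O)CCc1ccncc1-c1ccc2ccccc2c1`: 50.5 nM

Compound 2 gives the lowest of the three numbers in this assay. Compound 3 is within the scatter of it, so the two cannot be ordered; compound 1 stands beyond the scatter, a gap that is not a single-point change and so carries no attribution.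

The next compound, compound 4, is `Cn1ccc2cc(-c3cnccc3/C=C/C(=O)N3CCOCC3)ccc21`. It differs from compound 2 in one place:

morpholin-4-yl in place of hydroxy on a carbonyl carbon

For the measured compounds named here, no one-place step between measured compounds exists to calibrate this change. For compound 4 a step of a 1.7-fold higher number from compound 2 to compound 4 (0.23 log units; within the scatter) is expected, that is none clearly beyond the scatter, with the wider range reflecting the absence of a precedent. Compound 4 is estimated at 45 nM, between 12 nM and 150 nM.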

Compound 4, half-maximal inhibitory concentration: 247 nM
For compound 4 the middle estimate is 5.5-fold (0.74 log units) below the measured one, outside the stated range (above it).
By their numbers in this assay, from the lowest: compounds 2 and 3 (each within the scatter of the next); then compound 1; then compound 4.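

For the compounds shown here, the step of a 9.2-fold higher number from compound 2 to compound 4 (0.96 log units; beyond the scatter) in this assay is the only one-place change so far. It shows that, on this carbonyl carbon, morpholin-4-yl does not serve as an equivalent of hydroxy: the carboxy to (morpholin-4-yl)carbonyl change weakens inhibition beyond the scatter. No supporting measurement offers a reason for this step.

As far as these compounds go, it remains open whether the shift follows from removing the hydroxy or from the morpholine ring itself. A primary amide or a dimethylamide on the same carbonyl carbon would help separate the two.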